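Swapping the Pentyloxy Chain End for 7-Formylheptyl

The source may report more compounds than this note shows. Statements on the series, on what has been measured and on what is new or still open speak of the compounds shown alone.

Three compounds that share a core and differ in the long chain have been tested in a functional assay on K562 cells (Homo sapiens) for antiproliferative activity; on this read-out lower numbers stand for stronger inhibition of growth and higher numbers for weaker inhibition of growth. Compound 1 `COCCCCCCCCCCC/C=C1\CC(CO)(COC(=O)C(C)(C)C)OC1=O` gives 0.516 ug/mL, compound 2 `CCCCCCCCC(O)CCCCCC/C=C1\CC(CO)(COC(=O)C(C)(C)C)OC1=O` gives 7.3 ug/mL and compound 3 `CCCCCOCCCCCCC/C=C1\CC(CO)(COC(=O)C(C)(C)C)OC1=O` gives 1.15 ug/mL, which puts compound 3 in the middle of the three numbers.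

Compound 4 `CC(C)(C)C(=O)OCC1(CO)C/C(=C\CCCCCCCCCCCCCCC=O)C(=O)O1` changes the chain of compound 3 once more: 7-formylheptyl in place of pentyloxy on a saturated chain carbon, seven bonds along the chain from a double-bonded chain carbon. The new group stands seven bonds along the chain from a double-bonded chain carbon.

For the measured compounds named here, three measured steps bear on this change, all of them in the same chain. The modest ones are a 2.2-fold higher number from compound 1 to compound 3 (0.35 log units; beyond the scatter) and a 6.3-fold lower number from compound 2 to compound 3 (0.80 log units; beyond the scatter), while the large one is a 14-fold higher number from compound 1 to compound 2 (1.15 log units; beyond the scatter). None of them introduces a formyl group, so they give only a scale. Compound 4 lacks the hydroxyl on the chain of compound 2, so the large step, a 14-fold higher number from compound 1 to compound 2 (1.15 log units; beyond the scatter), is a poor guide here, and a modest step at most is expected.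

The estimated step is a 1.6-fold higher number from compound 3 to compound 4 (0.19 log units; within the scatter), a small rise expected to stay within the scatter. For compound 4 the expected value is 1.8 ug/mL, with an estimated range from 0.5 ug/mL to 6.5 ug/mL.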

Compound 4, concentration for 50% growth inhibition: 5.11 ug/mL
Estimate against measurement, compound 4: 2.8-fold (0.45 log units) below; the range from low to high includes it.
By their numbers in this assay, from the lowest: compound 1; then compound 3; then compounds 4 and 2 (each within the scatter of the next).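

In this assay, the exchange at this place, on a saturated chain carbon seven bonds along the chain from a double-bonded chain carbon, is not neutral: 7-formylheptyl in place of pentyloxy gives a 4.4-fold higher number from compound 3 to compound 4 (0.65 log units; beyond the scatter). The 8-formyloctyl chain also cannot be told apart from the 1-hydroxynonyl chain, with a 1.4-fold lower number from compound 2 to compound 4 (0.15 log units; within the scatter), so a formyl chain end without the hydroxyl still falls level with the hydroxylated chain rather than with the two chains that carry an ether oxygen. Measured against the methoxy-ended chain, 3-formylpropyl in place of methoxy gives a 9.9-fold higher number from compound 1 to compound 4 (1.00 log units; beyond the scatter), so among these four compounds the two lowest numbers belong to the ether chains, and no compound shown goes against that.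

The compounds shown do not tell whether a carboxylic acid or an amine at the same chain end would fall with the ether chains or with the formyl chain. No measurement shown accounts for the difference between the formyl and ether chains.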